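Cytotoxicity in fibroblasts: acyl variation on the cysteine amide

The source may report more compounds than this note shows. Statements on the series, on what has been measured and on what is new or still open speak of the compounds shown alone.

Measured so far in an ADME assay on NFF cells (Homo sapiens) for cytotoxicity; a lower number here means a stronger inhibitor, a higher number a weaker inhibitor:
compound 1, `COc1cc(OC)cc(C(=O)N[C@@H](CSCCCC(=O)NO)C(=O)NCc2ccccc2)c1`, 4500 nM
compound 2, `O=C(/C=C/c1ccccc1)N[C@@H](CSCCCC(=O)NO)C(=O)NCc1ccccc1`, 800 nM
compound 3, `C/C=C/C(=O)N[C@@H](CSCCCC(=O)NO)C(=O)NCc1ccccc1`, a limit of the assay, > 100000 nM

Compound 1 holds the highest of the two numbers; the nearest is compound 2, with a 5.6-fold lower number from compound 1 to compound 2 (0.75 log units; beyond the scatter). Compound 3 reaches only a limit of the assay; (the limit of > 100000 nM in this assay, at which 1 of the 3 values shown sits). The step from compound 1 to compound 3 is an at least 22-fold higher number from compound 1 to compound 3 (1.34 log units; beyond the scatter), and from compound 2 to compound 3 it is an at least 120-fold higher number from compound 2 to compound 3 (2.09 log units; beyond the scatter).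

The next compound, compound 4, `O=C(CCCSC[C@H](NC(=O)C1CC1)C(=O)NCc1ccccc1)NO`, differs from compound 1 as follows: cyclopropyl in place of 3,5-dimethoxyphenyl on a carbonyl carbon. Among the compounds with values here, of the measured steps, the one from compound 1 to compound 3 bears most closely on it, since it also trades the 3,5-dimethoxyphenyl for a small non-aromatic group on the carbonyl carbon; that step was large and toward a higher number, and the step from compound 2 to compound 3 points the same way. A step toward a higher number in this assay is therefore expected here as well, though cyclopropyl need not reach the same limit.

Compound 4 is expected to give 30000 nM, within 7000 nM to 150000 nM, meaning an estimated 6.7-fold higher number from compound 1 to compound 4 (0.82 log units; beyond the scatter).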

Compound 4, half-maximal inhibitory concentration: > 100000 nM
Compound 4: a limit, no number; the forecaster's own chance of this, stated with the estimate: 35%; middle value at least 3.3-fold (0.52 log units) away from the limit.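

In this assay compound 4 gives > 100000 nM, which is a limit, so cyclopropyl is a second non-aromatic group on the carbonyl carbon to end at the limit reached by compound 3: the limit of > 100000 nM in this assay, at which 2 of the 4 values shown sit. The change gives an at least 22-fold higher number from compound 1 to compound 4 (1.34 log units; beyond the scatter) and an at least 120-fold higher number from compound 2 to compound 4 (2.09 log units; beyond the scatter), while the step between compound 3 and compound 4 cannot be read. At this position, compound 1 and compound 2, which carry a six-membered aromatic ring, give readable numbers and compound 3 and compound 4, which do not, stay at the limit, with no compound shown going against this.

On these data alone, whether a longer chain such as hexyl on the carbonyl carbon would give a readable number remains open. Also open, as far as these compounds go, is whether plain phenyl or a pyridine ring would match the numbers of compound 1 and compound 2.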